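The source may report more compounds than this note shows. Statements on the series, on what has been measured and on what is new or still open speak of the compounds shown alone.

Measured in a functional assay on CCRF-CEM cells (Homo sapiens) for cytotoxicity (on this read-out higher numbers stand for weaker inhibition and lower numbers for stronger inhibition), each entry a limit and not a number:
Compound 1 `Nc1nc(O)c2ncn([C@@H]3S[C@H](CO)[C@H]3CO)c2n1` gives > 100000 nM
Compound 2 `Nc1ncnc2c1ncn2[C@H]1S[C@@H](CO)[C@@H]1CO` gives > 100000 nM
Compound 3 `OC[C@H]1[C@H](CO)S[C@@H]1n1cnc2c(O)ncnc21` gives > 100000 nM

Compound 3 is known only as a limit, > 100000 nM. Compound 4 `Nc1nc(O)c2ncn([C@H]3S[C@@H](CO)[C@@H]3CO)c2n1` differs from it by amino in place of hydrogen on an aromatic carbon. Within the data shown here, the one measured step, a step that the two limits leave unreadable from compound 2 to compound 3, is a different change, hydroxy in place of amino on an aromatic carbon, and offers no size to carry over. Among the measured compounds shown here, the only other guide is the limit of > 100000 nM in this assay, at which 3 of the 3 values shown sit. On that basis, no step beyond the scatter is expected in this assay, in either direction. The estimated step is a number no higher from compound 3 to compound 4 (the limit leaves the size open). Compound 4 is estimated at 100000 nM, with an expected range from 40000 nM to 200000 nM, and will most likely be reported as a limit again.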

Compound 4, half-maximal inhibitory concentration: > 100000 nM
Compound 4 was reported as a limit; the forecaster's own chance of this, stated with the estimate: 85%; the middle value sits exactly at the limit.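

Compound 4, like compounds 1 and 3, is known in this assay only as a limit, so neither its step from compound 3 nor its step from compound 1 can be read. Left open is whether the amino group of compound 4 or the mirror-image relation of compounds 1 and 4 alters the result in this assay at all.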